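Carbonyl substituent swap from compound 3 to compound 4

This account rests on a few compounds, and the source may have more. Where it says the series, first, only, none or still open, it means among the compounds named here.

Compound 3 `CCC/N=C1\S/C(=C\c2ccc(C(=O)NCC(=O)N(C)C)cc2)C(=O)N1c1ccccc1O` has no numeric half-life in an ADME assay on a cell-free system (plasma, Homo sapiens) for metabolic stability, at 37 degrees C; a lower number here means that the compound disappears faster, a higher number that the compound lasts longer: compound 3 gives > 3 h, which is a limit. Among the compounds with values here, the series so far rests on (the limit of > 3 h in this assay, at which 3 of the 3 values shown sit). The change to compound 4 `CCC/N=C1\S/C(=C\c2ccc(C(=O)OCC(O)CO)cc2)C(=O)N1c1ccccc1O` is 2,3-dihydroxypropoxy in place of ((dimethylcarbamoyl)methyl)amino on a carbonyl carbon.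

Within the data shown here, only one measured step involves a change on this carbonyl carbon: a step that the two limits leave unreadable from compound 1 to compound 2, between compound 1 `CCC/N=C1\S/C(=C\c2ccc(C(=O)OC)cc2)C(=O)N1c1ccccc1C` and compound 2 `CCC/N=C1\S/C(=C\c2ccc(C(=O)NCCO)cc2)C(=O)N1c1ccccc1C`. It gives no size to carry over. Compound 2 gives > 3 h, which is also a limit. Compound 1 carries methoxy on the same carbonyl carbon and gives > 3 h, again a limit. That result is the closest support for expecting compound 4 to stay long-lived in this assay, though the core of compound 1 is not identical.

With compound 3 at a limit, a readable change could only be downward, and no large fall is expected. The expected change is a number no higher from compound 3 to compound 4 (the limit leaves the size open). For compound 4 the estimated half-life is 3 h, with an expected range of 1 h to 6 h.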

Compound 4, half-life in the Homo sapiens assay: > 3 h
Compound 4: no number, only a limit; the forecaster's own chance of this, stated with the estimate: 55%; the middle value sits exactly at the limit.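

In the Homo sapiens assay compound 3 gives only a limit (> 3 h). In the Homo sapiens assay compound 4 also gives only a limit (> 3 h). Within the data shown here, no step between them can be read. In a physicochemical assay for lipophilicity, read by HPLC, measured as chromatographic lipophilicity (on this read-out lower numbers stand for lower lipophilicity and higher numbers for higher lipophilicity), compound 3 gives 1.9 and compound 4 gives 1.8 and the two lie within the scatter of each other. Whether any change on this carbonyl carbon brings the half-life to a readable number stays open: the limit of > 3 h in the Homo sapiens assay, at which 4 of the 4 values shown sit.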